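This account rests on a few compounds, and the source may have more. Where it says the series, first, only, none or still open, it means among the compounds named here.

Working notes on the series. In a physicochemical assay for lipophilicity, read by HPLC, at pH 7.4 (on this read-out higher numbers stand for higher lipophilicity and lower numbers for lower lipophilicity), compound 1 `COCCOc1cc2oc(=O)n(CCC(=O)O)c2cc1Cl` gives 0.88, compound 2 `O=C(O)CCn1c(=O)oc2cc(OCC3CCC3)c(Cl)cc21` gives 2.9, and compound 3 `Cc1cccc([C@@H](C)Oc2cc3oc(=O)n(CCC(=O)O)c3cc2Cl)n1` gives 2.12. Compound 3 is the second highest of the three: its nearest neighbour is compound 2, which stands higher, and the furthest is compound 1, which stands lower. For the measured compounds named here, the only one-place step measured so far, a number 2.02 log units higher from compound 1 to compound 2 (beyond the scatter), shows that swapping the group on the saturated chain carbon bound to an oxygen on the aromatic ring moves this assay a long way.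

Compound 4 `C[C@@H](Oc1cc2oc(=O)n(CCC(=O)O)c2cc1Cl)c1ncco1` differs from compound 3 at that same position: 1,3-oxazol-2-yl in place of 6-methylpyridin-2-yl on a saturated chain carbon bound to an oxygen on an aromatic ring and a saturated chain carbon. Going by the values given here, no measured step covers a change of this kind, so the expectation rests on the counts of the change and on the fact that compound 1, with the smallest group at that carbon, gives the lowest number. Fewer heavy atoms and one more hydrogen-bond acceptor enter, so a drop beyond the scatter is expected, smaller than the step from compound 1 to compound 2. For compound 4 the expected step is a number 1.07 log units lower from compound 3 to compound 4 (beyond the scatter), giving an estimate of 1.05, between 0.45 and 1.65.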

Compound 4, distribution coefficient: 1.11
Beside the measured number, compound 4's estimate is 0.06 log units below it, within the range that was stated.
By their numbers in this assay, from the lowest: compounds 1 and 4 (each within the scatter of the next); then compound 3; then compound 2.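

With the saturated chain carbon kept, exchanging 6-methylpyridin-2-yl for 1,3-oxazol-2-yl gives a number 1.01 log units lower from compound 3 to compound 4 (beyond the scatter) in this assay, so the identity of the aromatic ring alone can produce a large step at this position. Carrying an aromatic ring does not by itself fix the reading: replacing the group with a four-membered non-aromatic ring gives a number 1.79 log units lower from compound 2 to compound 4 (beyond the scatter) and the step from the ringless group is a number 0.23 log units higher from compound 1 to compound 4 (within the scatter), which places compound 4 level with compound 1 despite their different groups. Nothing available explains these steps.

The compounds shown leave open how much of the change belongs to the methyl group and how much to the ring, as neither a plain pyridin-2-yl nor a methyl-substituted 1,3-oxazol-2-yl appears here. Also open, as far as these compounds go, is how an amine or a longer chain on this carbon would read.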